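A few compounds are considered here, and "the series" means these few. Any claim that something is new, unique, unknown or untested is made for them only; others in the source may bear on it.

Of the compounds shown here, two from this set have been tested in an ADME assay on MDBK cells (Bos taurus) for cytotoxicity; a lower number here means that less compound is tolerated, a higher number that more compound is tolerated. Compound 1 `Fc1cccc(F)c1Cn1c(-c2c(F)cccc2F)nc2cnccc21` did not reach a measurable value: in this assay compound 1 gives > 100000 nM, which is a limit of the assay and not a number. Compound 2 `COc1cccc(Cn2ccc3nc(-c4ccccc4)nc-3c2)c1` stands in the same place: in this assay compound 2 gives > 100000 nM, again a limit rather than a number. Both results fall under (the limit of > 100000 nM in this assay, at which 2 of the 2 values shown sit).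

Compound 3 `N#Cc1ccccc1Cn1ccc2nc(-c3ccccc3)nc-2c1` has not yet been measured in this assay. It differs from compound 2 in one place: 2-cyanophenyl in place of 3-methoxyphenyl on a saturated chain carbon bound to an aromatic nitrogen. For the measured compounds named here, no step between measured compounds exists here, so the expectation for compound 3 rests on the two limits alone. In this assay compound 3 is expected to remain at the limit, with an estimated 100000 nM in a range from 40000 nM to 250000 nM. The expected step of a number no higher from compound 2 to compound 3 (the limit leaves the size open) is therefore none beyond the scatter.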

Compound 3, half-maximal cytotoxic concentration: > 100000 nM
Compound 3 ended at the assay's limit (the forecaster's own chance of this, stated with the estimate: 70%); the middle value sits exactly at the limit.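

Compound 3, like compound 2, stands at a limit of this assay and not at a number, so no step between compound 2 and compound 3 can be read: the limit of > 100000 nM in this assay, at which 3 of the 3 values shown sit.

The compounds shown leave open whether 2-cyanophenyl in place of 3-methoxyphenyl changes the tolerated concentration at all.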